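From a primary amide to a dimethylamide

This account rests on a few compounds, and the source may have more. Where it says the series, first, only, none or still open, it means among the compounds named here.

Measured in an assay on a protein complex for inhibition of CDK8/Cyclin C (Homo sapiens), with a stated time of 1 h; a lower number here means a stronger inhibitor, a higher number a weaker inhibitor:
- compound 2 `COC1CN(C(=O)/C=C/c2ccncc2-c2ccc3ccccc3c2)C1` gives 42.8 nM
- compound 3 `NC(=O)/C=C/c1ccncc1-c1ccc2ccccc2c1` gives 10.5 nM
- compound 1 `O=C(O)[C@@H]1CCCN1C(=O)/C=C/c1ccncc1-c1ccc2ccccc2c1` gives "not determined" (no result reported)

Compound 3 holds the lowest number of the two measured; compound 2 sits higher, as seen in a 4.1-fold lower number from compound 2 to compound 3 (0.61 log units; beyond the scatter). Compound 4 `CN(C)C(=O)/C=C/c1ccncc1-c1ccc2ccccc2c1` differs from compound 3 by dimethylamino in place of amino on a carbonyl carbon. For the measured compounds named here, the only measured step touching this carbonyl carbon is a 4.1-fold lower number from compound 2 to compound 3 (0.61 log units; beyond the scatter), where trimming the larger ring-bearing group down to amino lowered the number by a modest amount. For compound 4 a modest rise is expected, a 2.9-fold higher number from compound 3 to compound 4 (0.46 log units; beyond the scatter), with a smaller shift also plausible. Compound 4 is therefore estimated at 30 nM, within 10 nM to 90 nM in this assay .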

Compound 4, half-maximal inhibitory concentration: 30.1 nM
Estimate against measurement, compound 4: 1.0-fold (0.00 log units) below, within the range that was stated.
By their numbers in this assay, from the lowest: compound 3; then compounds 4 and 2 (each within the scatter of the next).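

On this carbonyl carbon, dimethylamino in place of amino brings a 2.9-fold higher number from compound 3 to compound 4 (0.46 log units; beyond the scatter), so trimming the group does not by itself account for the low number of compound 3. Dimethylamino in place of 3-methoxyazetidin-1-yl brings a 1.4-fold lower number from compound 2 to compound 4 (0.15 log units; within the scatter), so these two groups, neither with a hydrogen-bond donor, cannot be told apart here. No measurement shown explains these results. Methylamino, with one methyl group on the nitrogen, would test whether the number rises with the first methyl or only the second. From the compounds shown here alone, whether longer chains on that nitrogen behave like dimethylamino also remains open.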